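Removing the difluoromethoxy group from compound 3

The source may report more compounds than this note shows. Statements on the series, on what has been measured and on what is new or still open speak of the compounds shown alone.

Of the compounds shown here, three have been measured in a functional assay on cells (Erythrocyte, Homo sapiens); on this read-out higher numbers stand for weaker inhibition and lower numbers for stronger inhibition. Compound 1, `COc1cc(CS(=O)(=O)c2nc3cc(OC(F)F)ccc3[nH]2)ccc1OCc1ncc(C)c(OC)c1C`, gives 1420 nM in this assay. Compound 2, `COc1ccc2[nH]c(S(=O)(=O)Cc3ccc(OCc4nccc(OC)c4OC)c(OC)c3)nc2c1`, gives 898 nM in this assay. Compound 3, `COCCCOc1ccnc(COc2ccc(CS(=O)(=O)c3nc4cc(OC(F)F)ccc4[nH]3)cc2OC)c1C`, gives 142 nM in this assay, the lowest of the three numbers; the numbers of compound 2 and of compound 1 are both higher than that of compound 3 by more than the usual scatter, compound 1 being the furthest away. These three compounds differ from each other in several places at once. Going by the values given here, no single-change step between them can be drawn.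

Compound 4, `COCCCOc1ccnc(COc2ccc(CS(=O)(=O)c3nc4ccccc4[nH]3)cc2OC)c1C`, has not yet been measured. It differs from compound 3 in a single place: hydrogen in place of difluoromethoxy on an aromatic carbon. No comparable change is present among the measured compounds, so the direction of the step rests on the change itself rather than on a shown step. The author expects a modest step from compound 3 to compound 4, toward a somewhat higher number, of a 1.8-fold higher number from compound 3 to compound 4 (0.25 log units; within the scatter) in this assay, but one that may well fall within the scatter. On that basis compound 4 is estimated at 250 nM in this assay, with a range from 80 nM to 800 nM.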

Compound 4, half-maximal inhibitory concentration: 355 nM
Estimate against measurement, compound 4: 1.4-fold (0.15 log units) below; low and high end bracket the measured number.
By their numbers in this assay, from the lowest: compound 3; then compound 4; then compounds 2 and 1 (each within the scatter of the next).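

In this assay, hydrogen in place of difluoromethoxy gives a 2.5-fold higher number from compound 3 to compound 4 (0.40 log units; beyond the scatter), the first comparison among these compounds that isolates a single place, so this change on the aromatic carbon can now be read apart from the differences elsewhere in the molecules. The step shows that difluoromethoxy makes a modest but real difference on this read-out, yet it is not required for inhibition, since compound 4, which has only hydrogen there, still gives 355 nM. Nothing measured here accounts for the size or direction of the step.

The compounds shown do not reveal whether the step is specific to difluoromethoxy or whether another group on the same carbon, such as trifluoromethyl, a nitrile or a single fluorine, would give a similar number. They also leave open whether removing difluoromethoxy would cost as much on the other side chain carried by compound 1, where the same group is present but no matching compound with hydrogen is shown.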